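Bromo for methyl on the arylsulfanyl ring of compound 1

The source may report more compounds than this note shows. Statements on the series, on what has been measured and on what is new or still open speak of the compounds shown alone.

Measured compounds:
- Compound 1, `Cc1ccc(S/C(=C/c2ccc(Cl)cc2)C(=O)c2ccc(Br)cc2)cc1`: 10000 nM
- Compound 2, `CSc1ccc(/C=C(/Sc2ccc(C)cc2)C(=O)c2ccc(Br)cc2)cc1`: 50000 nM
- Compound 3, `Cc1ccc(S/C(=C/c2c(O)cc(O)cc2O)C(=O)c2ccc(Br)cc2)cc1`: > 100000 nM

In a functional assay on DU-145 cells (Homo sapiens) for inhibition, read by trypan blue exclusion, with a stated time of 96 h (on this read-out lower numbers stand for stronger inhibition of growth and higher numbers for weaker inhibition of growth), compound 1 gives the lowest of the two numbers shown. Compound 2 sits nearest, with a 5.0-fold higher number from compound 1 to compound 2 (0.70 log units; beyond the scatter). Compound 3 is reported only as a limit, (the limit of > 100000 nM in this assay, at which 1 of the 3 values shown sits), so its value is not a number, and the step of an at least 10-fold higher number from compound 1 to compound 3 (1.00 log units; beyond the scatter) is itself a floor; the step of an at least 2.0-fold higher number from compound 2 to compound 3 (0.30 log units; that floor lies within the scatter) has a floor that lies within the scatter.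

Compound 4, `O=C(/C(=C\c1ccc(Cl)cc1)Sc1ccc(Br)cc1)c1ccc(Br)cc1`, differs from compound 1 by bromo in place of methyl on an aromatic carbon, that is, on the (4-methylphenyl)sulfanyl group rather than on the 4-chlorophenyl group. Going by the values given here, none of the measured steps touches that ring: the step from compound 1 to compound 2 and the step from compound 1 to compound 3 both alter the aryl on the double-bonded chain carbon, so they speak only indirectly to this change. Among the compounds with values here, with no measured step on the arylsulfanyl ring, a step beyond the scatter is not expected in either direction.

Compound 4 is therefore estimated at 10000 nM, within 4000 nM to 30000 nM, which means an expected step of no change at the digits printed from compound 1 to compound 4 (within the scatter).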

Compound 4, concentration for 50% growth inhibition: 1000 nM
For compound 4 the middle estimate is 10-fold (1.00 log units) above the measured one; measured number below the stated range.
By their numbers in this assay, from the lowest: compound 4; then compound 1; then compound 2. At a limit, above all of these: compound 3.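

In this assay, going by these compounds alone, the arylsulfanyl ring proves to be a position that responds: replacing (4-methylphenyl)sulfanyl with (4-bromophenyl)sulfanyl gives a 10-fold lower number from compound 1 to compound 4 (1.00 log units; beyond the scatter) on this ring, which no earlier step had touched. The earlier steps changed only the aryl on the double-bonded chain carbon, and both raised the number, so this is the first change shown that lowers it from compound 1. Nothing measured here explains the step, in which one heavy atom replaces another and neither group carries a hydrogen-bond donor or acceptor.

The compounds shown leave open whether this step is specific to bromo or would also appear with fluoro, iodo, methoxy or an amine on the same ring. They also do not tell whether the (4-bromophenyl)sulfanyl group would lower the number in the same way alongside the 4-(methylsulfanyl)phenyl group of compound 2 or the 2,4,6-trihydroxyphenyl group of compound 3.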